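A methyl group added to compound 3

The source may report more compounds than this note shows. Statements on the series, on what has been measured and on what is new or still open speak of the compounds shown alone.

Compound 1 `Cc1ccccc1Nc1nc(Nc2cccnc2)ncc1Cl` gives 38600 nM
Compound 2 `Cc1ccccc1Nc1nc(NC2CC2)ncc1Cl` gives > 100000 nM as a limit
Compound 3 `Cc1ccccc1Nc1nc(Nc2ccccc2)ncc1Cl` gives > 100000 nM as a limit

All three compounds were tested in a functional assay on Jurkat cells (Homo sapiens) for inhibition, read by CCK-8 assay, with a stated time of 48 h (on this read-out higher numbers stand for weaker inhibition of growth and lower numbers for stronger inhibition of growth), and differ in one place. Compound 3 has only a limit as its result and stands at the limit of > 100000 nM in this assay, at which 2 of the 3 values shown sit, without a number.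

Compound 4 `Cc1ccc(Nc2ncc(Cl)c(Nc3ccccc3C)n2)cc1` is not yet measured. It carries methyl in place of hydrogen on an aromatic carbon of compound 3, so that phenyl becomes 4-methylphenyl (methyl in place of hydrogen on an aromatic carbon).

The measured steps all concern the group in this same place. Replacing pyridin-3-yl with phenyl gave an at least 2.5-fold higher number from compound 1 to compound 3 (0.41 log units; beyond the scatter) and replacing it with cyclopropyl gave an at least 2.5-fold higher number from compound 1 to compound 2 (0.41 log units; beyond the scatter) so both lie beyond the scatter. The remaining comparison is a step that the two limits leave unreadable from compound 2 to compound 3 and adds no size. On these data alone, none of these steps adds a methyl, and the true standing of compound 3 is unknown, so no step beyond the scatter is expected in either direction. The expected change is an at least 1.1-fold lower number from compound 3 to compound 4 (0.04 log units; that floor lies within the scatter) and no more. Compound 4 may well return only a limit too. In this assay compound 4 is estimated at 90000 nM with an expected range from 40000 nM to 200000 nM as its bounds.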

Compound 4, concentration for 50% growth inhibition: > 100000 nM
Compound 4 ended at the assay's limit (the forecaster's own chance of this, stated with the estimate: 65%); middle value at least 1.1-fold (0.04 log units) away from the limit.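

In this assay, a methyl on the phenyl ring, para to a large group, does not bring compound 4 to a measurable number, and the steps among compound 2, compound 3 and compound 4 cannot be read. Set against pyridin-3-yl, the 4-methylphenyl group gives an at least 2.5-fold higher number from compound 1 to compound 4 (0.41 log units; beyond the scatter), so pyridin-3-yl remains the only group at this place with a number rather than a limit. Compound 4 now shares a single mark with compound 2 and compound 3, and that mark is a limit of the assay, not a number: the limit of > 100000 nM in this assay, at which 3 of the 4 values shown sit.

On these data alone, the size of any effect of the methyl remains unknown, as does whether the same methyl would change the result on a ring that gives a number, such as the pyridin-3-yl of compound 1. Also open, as far as these compounds go, is whether an amine, a morpholine or a carboxylic acid on the phenyl ring of compound 3 would give a number in this assay rather than another limit.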